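The source may report more compounds than this note shows. Statements on the series, on what has been measured and on what is new or still open speak of the compounds shown alone.

In a functional assay on A549 cells (Homo sapiens) for cytotoxicity, read by sulforhodamine B assay, with a stated time of 48 h, tested at 100 uM (a lower number here means a stronger effect, a higher number a weaker effect of the compound at the concentration tested), compound 2, `COc1cc(-c2cc(/C=C/C(=O)c3ccc(Cl)c(Cl)c3)[nH]n2)cc(OC)c1OC`, gives 2%, the highest of the three numbers recorded. Compound 1, `COc1ccc(-c2cc(/C=C/C(=O)c3ccc(OC)c(OC)c3)[nH]n2)cc1`, gives -45% in this assay, a number well beyond the scatter below that of compound 2. Compound 3, `COc1ccc(-c2cc(/C=C/C(=O)c3ccc(N)cc3)[nH]n2)cc1OC`, gives -76% in this assay, the lowest of the three and the furthest from compound 2.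

Compound 4, `COc1ccc(C(=O)/C=C/c2cc(-c3cc(OC)c(OC)c(OC)c3)n[nH]2)cc1OC`, has not yet been measured. It differs from compound 2 in one place: 3,4-dimethoxyphenyl in place of 3,4-dichlorophenyl on a carbonyl carbon. Among the measured compounds shown here, no step between two measured compounds matches this change exactly, so the expectation rests on the fact that compound 1 carries the same 3,4-dimethoxyphenyl on its carbonyl carbon and gives -45% in this assay. The step is therefore expected to be beyond the scatter and toward a lower number. Compound 4 is expected to give about -35% in this assay, within a range from -70% to 5%. This means an estimated step of a number 37 percentage points lower from compound 2 to compound 4 (beyond the scatter) in this assay.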

Compound 4, a percentage reported as activity, at one concentration (the size of the read-out at that concentration, not a potency): -78%
For compound 4 the middle estimate is 43 percentage points above the measured one; measured number outside the range, below it.
By their numbers in this assay, from the lowest: compounds 4 and 3 (each within the scatter of the next); then compound 1; then compound 2.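

In this assay, putting 3,4-dimethoxyphenyl in place of 3,4-dichlorophenyl on a carbonyl carbon gives a number 80 percentage points lower from compound 2 to compound 4 (beyond the scatter), the first reading of a single change among these compounds. It shows that, with the rest of the molecule held fixed, the group on this carbonyl carbon alone can shift the read-out by a large margin at the concentration tested, which compounds 1, 2 and 3 could not show, as they differ from one another in more than one place. No measurement given here accounts for the size of this step.

From the compounds shown here alone, what a 3,4-dihydroxyphenyl or a 3,4-difluorophenyl on the same carbonyl carbon would give remains open. Also open, going by these compounds, is whether the same exchange produces a step of similar size on the core of compound 1, and how the compounds would compare as potencies rather than at one concentration.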